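This account rests on a few compounds, and the source may have more. Where it says the series, first, only, none or still open, it means among the compounds named here.

Three compounds have been measured in a functional assay on Capan-2 cells (Homo sapiens) for inhibition, read by MTT assay, with a stated time of 72 h; on this read-out lower numbers stand for stronger inhibition of growth and higher numbers for weaker inhibition of growth:
Compound 1, `COc1ccc(CNCCCNS(=O)(=O)c2cc(C(F)(F)F)cc(C(F)(F)F)c2)cc1OC`, gives 15000 nM.
Compound 2, `CC(C)(C)c1ccc(CNCCCNS(=O)(=O)c2cc(C(F)(F)F)cc(C(F)(F)F)c2)cc1`, gives 2100 nM.
Compound 3, `COc1cccc(CNCCCNS(=O)(=O)c2cc(C(F)(F)F)cc(C(F)(F)F)c2)c1`, gives 6400 nM.

On these numbers compound 3 stands second highest of the three. Its nearest neighbour is compound 1, from which a 2.3-fold lower number from compound 1 to compound 3 (0.37 log units; beyond the scatter), and its furthest is compound 2, where a 3.0-fold higher number from compound 2 to compound 3 (0.48 log units; beyond the scatter). The unmeasured compound 4, `O=S(=O)(NCCCNCc1ccc(C(F)(F)F)cc1)c1cc(C(F)(F)F)cc(C(F)(F)F)c1`, differs from compound 3 in one place: 4-(trifluoromethyl)phenyl in place of 3-methoxyphenyl on a saturated chain carbon bound to an amine nitrogen. Going by the values given here, two measured steps bear on this change, both at the same saturated chain carbon bound to the amine nitrogen. The step of a 7.1-fold lower number from compound 1 to compound 2 (0.85 log units; beyond the scatter) and the step of a 3.0-fold higher number from compound 2 to compound 3 (0.48 log units; beyond the scatter) show that the 4-(tert-butyl)phenyl of compound 2, which carries no methoxy, gave the lowest number of the three, whereas the methoxy-bearing groups of compound 1 and compound 3 gave higher numbers. Among the compounds with values here, compound 4 carries a 4-(trifluoromethyl)phenyl, again with no hydrogen-bond acceptor, so a modest step toward a lower number in this assay is expected, of roughly the size seen in a 3.0-fold higher number from compound 2 to compound 3 (0.48 log units; beyond the scatter) but reversed; no measured pair shows a trifluoromethyl at this place, so the size is uncertain. For compound 4 the estimated step is a 2.6-fold lower number from compound 3 to compound 4 (0.41 log units; beyond the scatter). Compound 4 is thus expected to give 2500 nM in this assay, with a range from 1000 nM to 7000 nM.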

Compound 4, concentration for 50% growth inhibition: 2000 nM
For compound 4 the middle estimate is 1.3-fold (0.10 log units) above the measured one; low and high end bracket the measured number.
By their numbers in this assay, from the lowest: compounds 4 and 2 (each within the scatter of the next); then compound 3; then compound 1.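

In this assay, 4-(trifluoromethyl)phenyl in place of 3-methoxyphenyl on a saturated chain carbon bound to an amine nitrogen gives a 3.2-fold lower number from compound 3 to compound 4 (0.51 log units; beyond the scatter), and the same group in place of 3,4-dimethoxyphenyl gives a 7.5-fold lower number from compound 1 to compound 4 (0.88 log units; beyond the scatter). The earlier compounds held only one group without methoxy at this place, whereas now a second one joins it: trifluoromethyl in place of tert-butyl on an aromatic carbon gives a 1.1-fold lower number from compound 2 to compound 4 (0.02 log units; within the scatter), so the two groups cannot be told apart here, and among these four compounds, both methoxy-bearing groups give higher numbers than both groups without methoxy, with no compound going against this. Nothing available explains this pattern in the numbers.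

The compounds shown leave open whether a plain phenyl, or a 4-methoxyphenyl, would stand with the groups without methoxy or with those carrying it, and how a ring bearing a nitrile or a carboxylic acid would read at this place. They also leave open whether the same order would hold with a longer chain in the shared core.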